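The compounds below may be only part of what the source reports. "The series", "measured", "known", "first", "only" and "open" are said of these compounds alone.

The measured compounds and their values in a functional assay on HEK293 cells for positive allosteric modulation of metabotropic glutamate receptor 5 (Rattus norvegicus), read by fluorescence and calcium flux (a higher number here means that more compound is needed for the effect, a lower number that less compound is needed), are these. Compound 1, `COc1ccccc1N1CCN(C(=O)COCc2ccccc2)CC1`: compound 1 gives 9200 nM. Compound 2, `O=C(COCc1ccccc1)N1CCN(c2ccccc2Cl)CC1`: compound 2 gives 820 nM. Compound 3, `COC(=O)c1ccccc1N1CCN(C(=O)COCc2ccccc2)CC1`: compound 3 gives only a limit of the assay, > 10000 nM.

Compound 3 thus stands at the limit (the limit of > 10000 nM in this assay, at which 1 of the 3 values shown sits); the move an at least 12-fold higher number from compound 2 to compound 3 (1.08 log units; beyond the scatter) is large, whereas an at least 1.0-fold higher number from compound 1 to compound 3 (0.03 log units; that floor lies within the scatter) lies within the scatter. Compound 4, `O=C(COCc1ccccc1)N1CCN(c2ccccc2[N+](=O)[O-])CC1`, carries a nitro group where compound 3 carries a methoxycarbonyl: nitro in place of methoxycarbonyl on an aromatic carbon. For the measured compounds named here, no measured step swaps these two groups directly; the nearest comparisons are the exchanges at the same position that gave an 11-fold lower number from compound 1 to compound 2 (1.05 log units; beyond the scatter) and an at least 12-fold higher number from compound 2 to compound 3 (1.08 log units; beyond the scatter), so this position tolerates a wide spread of outcomes. The nitro group matches the methoxycarbonyl group in hydrogen-bond donors and acceptors as counted, so no large change is expected in either direction. The step expected here, an at least 1.4-fold lower number from compound 3 to compound 4 (0.15 log units; that floor lies within the scatter), is modest. Compound 4 may again reach only the limit. Compound 4 is estimated at 7000 nM, between 1500 nM and 30000 nM.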

Compound 4, half-maximal effective concentration: 1800 nM
Estimate against measurement, compound 4: 3.9-fold (0.59 log units) above; measured number inside the range.
By their numbers in this assay, from the lowest: compound 2; then compound 4; then compound 1. At a limit, above all of these: compound 3.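

In this assay, nitro in place of methoxycarbonyl gives an at least 5.5-fold lower number from compound 3 to compound 4 (0.74 log units; beyond the scatter), so equal counts of hydrogen-bond donors and acceptors did not keep these two groups alike at this position. That step is only a floor, and compound 3 remains at a limit of the assay: the limit of > 10000 nM in this assay, at which 1 of the 4 values shown sits. Nitro also falls in the middle of the groups compared here, with a 2.2-fold higher number from compound 2 to compound 4 (0.34 log units; beyond the scatter) and a 5.1-fold lower number from compound 1 to compound 4 (0.71 log units; beyond the scatter), so chloro, nitro and methoxy are separated by steps that all lie beyond the scatter.

The compounds shown leave open whether other groups at this position, such as an amine or a carboxylic acid, would fall within this spread or outside it. They also leave open how far compound 3 actually lies from the others, and whether this order would hold with a longer chain in place of the benzyloxy-bearing side of the shared core.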